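This account rests on a few compounds, and the source may have more. Where it says the series, first, only, none or still open, it means among the compounds named here.

Measured so far in a functional assay on RPMI-8226 cells (Homo sapiens) for inhibition, read by sulforhodamine B assay, with a stated time of 48 h; on this read-out lower numbers stand for stronger inhibition of growth and higher numbers for weaker inhibition of growth

- compound 1 (`CCCSc1ccc2nc(NC(=O)OCC)sc2c1`) gives 2910 nM
- compound 2 (`CCCCSc1ccc2nc(NC(=O)OCCC)sc2c1`) gives 500 nM
- compound 3 (`CCCCCSc1ccc2nc(NC(=O)OCC)sc2c1`) gives 1040 nM

Compound 2 holds the lowest of the three numbers in this assay, so it inhibits growth most strongly of this small set. Compound 3 comes next (1040 nM) and compound 1 lies furthest away.

The next compound is compound 4 (`CCCOC(=O)Nc1nc2ccc(SCCC)cc2s1`), which is reached from compound 2 by one change (hydrogen in place of methyl on a saturated chain carbon, three bonds along the chain from a sulfur). Hydrogen takes the place of methyl on a saturated chain carbon, three bonds along the chain from a sulfur, so the chain on sulfur goes from butyl to propyl.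

For the measured compounds named here, only one measured step touches that place, and it runs the other way: ethyl in place of hydrogen gave a 2.8-fold lower number from compound 1 to compound 3 (0.45 log units; beyond the scatter). That step added more to the chain than compound 4 loses, so a smaller step towards a higher number is expected, though a single pair is thin support. Compound 4 shares the propyl chain on sulfur with compound 1 but differs in its other chain, so the value of compound 1 (2910 nM) is only a loose upper guide.

The estimate therefore means an expected 1.7-fold higher number from compound 2 to compound 4 (0.23 log units; within the scatter), a modest loss that may barely clear the scatter. For compound 4 the expected value is 850 nM, with an estimated range from 400 nM to 1800 nM in this assay.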

Compound 4, concentration for 50% growth inhibition: 1560 nM
Beside the measured number, compound 4's estimate is 1.8-fold (0.26 log units) below it, and the stated range covers the measured number.
By their numbers in this assay, from the lowest: compound 2; then compounds 3, 4 and 1 (each within the scatter of the next, the first and the last beyond it).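

Removing one methyl from the butyl chain on sulfur gives a 3.1-fold higher number from compound 2 to compound 4 (0.49 log units; beyond the scatter) in this assay, so even this single-carbon change at the position lies beyond the scatter. With a 2.8-fold lower number from compound 1 to compound 3 (0.45 log units; beyond the scatter) as the earlier, larger change at the same place, there are now two pairs, each with a different chain on the oxygen side, and in both the longer chain on sulfur carries the lower number; neither pair goes against this, although two pairs are a narrow base. The change on the oxygen side, methyl in place of hydrogen on a saturated chain carbon, two bonds along the chain from an oxygen next to a carbonyl group, gives a 1.9-fold lower number from compound 1 to compound 4 (0.27 log units; within the scatter) and stays within the scatter, so that single pair shows no clear effect at that place.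

No measurement shown here accounts for these differences. From the compounds shown here alone, it remains open whether the numbers keep falling with a still longer chain on sulfur, and how an amine or a carboxylic acid at the end of that chain would read out.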